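Methoxy to hydroxy on the aryl ring of compound 3

The compounds below may be only part of what the source reports. "The series", "measured", "known", "first", "only" and "open" are said of these compounds alone.

Three compounds share one core and differ only in the group on the aromatic carbon of the pendant aryl ring. Compound 1 `Cc1ccc(CN2C(=O)S/C(=C\c3ccc([N+](=O)[O-])cc3)C2=O)cc1` gives 11.4% in a functional assay on the whole organism (plasma) with Mus musculus as the target, with a stated time of 15 days, at a dose of 30 mg/kg by the oral route; a lower number here means a weaker effect, a higher number a stronger effect of the compound at the dose given. Compound 2 `Cc1ccc(CN2C(=O)S/C(=C\c3ccc(N(C)C)cc3)C2=O)cc1` gives 40.8%. Compound 3 `COc1ccc(/C=C2\SC(=O)N(Cc3ccc(C)cc3)C2=O)cc1` gives 50.8%, the top number of the three, though the gap a number 10 percentage points higher from compound 2 to compound 3 (within the scatter) lies within the scatter, so compound 2 and compound 3 cannot be told apart on these data. The two clear steps both run from compound 1: a number 29.4 percentage points higher from compound 1 to compound 2 (beyond the scatter) and a number 39.4 percentage points higher from compound 1 to compound 3 (beyond the scatter).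

Compound 4 `Cc1ccc(CN2C(=O)S/C(=C\c3ccc(O)cc3)C2=O)cc1` is not yet measured. It differs from compound 3 by hydrogen in place of methyl on an oxygen on an aromatic ring, that is, methoxy to hydroxy on the aryl ring. Among the compounds with values here, no measured pair shows this particular change; the steps at this position only show that replacing nitro moves the number a great deal, while dimethylamino and methoxy sit within the scatter of each other. Within the data shown here, a hydroxy group has no precedent here, so a step of modest size in either direction, or none, is plausible. Compound 4 is expected to give about 40%, within 20% to 60%, which corresponds to an expected step of a number 10.8 percentage points lower from compound 3 to compound 4 (beyond the scatter).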

Compound 4, a percentage reported as activity, at one dose (the size of the read-out at that dose, not a potency): 37.3%
The estimate for compound 4 lay 2.7 percentage points above the measured number; the range from low to high includes it.
By their numbers in this assay, from the lowest: compound 1; then compounds 4, 2 and 3 (each within the scatter of the next, the first and the last beyond it).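

In this assay, within the data shown here, methoxy to hydroxy gives the only step beyond the scatter among the groups other than nitro (a number 13.5 percentage points lower from compound 3 to compound 4 (beyond the scatter)), so removing the methyl from this oxygen can register in the read-out. Hydroxy and dimethylamino cannot be told apart (a number 3.5 percentage points lower from compound 2 to compound 4 (within the scatter)), leaving compound 2 within the scatter of both compound 3 and compound 4, although those two differ beyond it. Hydroxy also stands clear of nitro (a number 25.9 percentage points higher from compound 1 to compound 4 (beyond the scatter)), so all three replacements of nitro in this series exceed compound 1, but nothing available accounts for any of these steps.

The compounds shown leave open how an ethoxy group, a longer alkoxy chain, a primary amine or a carboxylic acid would read at this place. They also leave open whether the methoxy to hydroxy step would persist on a different core.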